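Series notes: aminothiophene ketones, agonist read-out, step to compound 3

This account rests on a few compounds, and the source may have more. Where it says the series, first, only, none or still open, it means among the compounds named here.

Measured so far:
compound 1 `Nc1scc(-c2cccc(Br)c2)c1C(=O)c1ccccc1` gives 76% in a functional assay on CHO cells for agonist activity at adenosine receptor A1 (Homo sapiens), read by fluorescence and ERK phosphorylation, with stated times of 30 min and 1.5 h, tested at 10 uM; on this read-out higher numbers stand for a stronger effect at the one concentration tested and lower numbers for a weaker effect
compound 2 `Nc1scc(-c2cccc(F)c2)c1C(=O)c1ccc(Cl)cc1` gives 90% in this assay

Compound 2 stands highest of the two numbers in hand; its nearest neighbour is compound 1, which sits lower by a gap beyond the usual scatter. Within the data shown here, no pair of measured compounds differs in only one place, so nothing measured yet describes a single change on this core.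

Compound 3 `Nc1scc(-c2cccc(Br)c2)c1C(=O)c1ccc(Cl)cc1` is not yet measured. It differs from compound 2 by bromo in place of fluoro on an aromatic carbon. The change is the same one that, cut one bond further out, reads 3-fluorophenyl to 3-bromophenyl. Compound 1 carries the bromo group but differs from compound 3 elsewhere as well. The value of compound 1, 76%, therefore cannot be read as the effect of this single change.

Among the measured compounds shown here, with no measured step of this kind, the expectation is that compound 3 lands near compound 2, within the scatter or a little below it, and the expected step from compound 2 to compound 3 is a number 6 percentage points lower from compound 2 to compound 3 (within the scatter). Compound 3 is thus estimated at 84%, with a range from 68% to 97%.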

Compound 3, a percentage reported as activity, at one concentration (the size of the read-out at that concentration, not a potency): 69%
Compound 3: the middle estimate sits 15 percentage points above what was measured; measured number inside the range.
By their numbers in this assay, from the lowest: compounds 3 and 1 (each within the scatter of the next); then compound 2.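

Among these compounds, with the rest of compound 2 held fixed, the change from 3-fluorophenyl to 3-bromophenyl gives the first single-place reading for this position in this assay: a number 21 percentage points lower from compound 2 to compound 3 (beyond the scatter), so the read-out here depends on which halogen the ring carries, at least with the chloro group present. The second single-place pair concerns the other aryl ring, where chloro in place of hydrogen gives a number 7 percentage points lower from compound 1 to compound 3 (within the scatter), a step that does not separate the two compounds when the bromo group is present. The two steps together therefore tie the high number of compound 2 to fluoro rather than bromo within this one pair, and no measurement at hand speaks to why the exchange has this effect.

The compounds shown leave open whether the fluoro-to-bromo step keeps its size without the chloro group, and whether chloro in place of hydrogen has any effect when fluoro occupies the other ring. They also leave open how the same aromatic carbon would read with hydrogen, chloro, methyl, methoxy or a nitrile in place of the halogen, so no trend across substituents can yet be drawn.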